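The source may report more compounds than this note shows. Statements on the series, on what has been measured and on what is new or still open speak of the compounds shown alone.

Measured compounds in a functional assay on HCT-116 cells (Homo sapiens) for cytotoxicity, read by MTT assay, with a stated time of 48 h; on this read-out higher numbers stand for weaker inhibition and lower numbers for stronger inhibition:
Compound 1 `COc1ccc(-c2nc(C(=O)/C=C\Nc3ccc4[nH]ccc4c3)c3ccccn23)cc1` gives 17400 nM.
Compound 2 `COc1ccc(N/C=C\C(=O)c2nc(-c3ccc(OC)cc3)n3ccccc23)cc1` reaches only the assay limit, > 30000 nM.

Among the compounds with values here, compound 1 carries the only numeric value in this assay; the other result is a limit, as the limit of > 30000 nM in this assay, at which 1 of the 2 values shown sits, records. Compound 3 `O=C(/C=C\Nc1ccc2[nH]ccc2c1)c1nc(-c2ccc(C(F)(F)F)cc2)n2ccccc12` differs from compound 1 by trifluoromethyl in place of methoxy on an aromatic carbon. Within the data shown here, the single measured step, an at least 1.7-fold higher number from compound 1 to compound 2 (0.23 log units; that floor lies within the scatter), alters the group on the amine nitrogen rather than the aryl ring attached to the shared core, so it does not bear directly on this change. No step beyond the scatter is therefore expected in this assay. Compound 3 is estimated near compound 1, at 15000 nM, within 5000 nM to 30000 nM, a step of a 1.2-fold lower number from compound 1 to compound 3 (0.06 log units; within the scatter).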

Compound 3, half-maximal inhibitory concentration: 27100 nM
For compound 3 the middle estimate is 1.8-fold (0.26 log units) below the measured one; low and high end bracket the measured number.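

In this assay, within the data shown here, trifluoromethyl in place of methoxy on the aryl ring gives a 1.6-fold higher number from compound 1 to compound 3 (0.19 log units; within the scatter) and is the first reading at this position. The two groups cannot be told apart here, so compound 1 and compound 3 read as equivalent, and this exchange on an aromatic carbon shows no effect beyond the scatter. Compound 2 remains a limit and not a number: the limit of > 30000 nM in this assay, at which 1 of the 3 values shown sits.

On these data alone, whether an amine or a carboxylic acid at this position would give a step beyond the scatter stays open. So does whether the exchange reads the same with 4-methoxyphenyl on the amine nitrogen.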